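Alkyne chain shortening and hydroxylation in the sulfonamide series

The compounds below may be only part of what the source reports. "The series", "measured", "known", "first", "only" and "open" are said of these compounds alone.

compound 1 `CCCCCCC#Cc1ccc(S(=O)(=O)Nc2cccc(-c3csc(NC(C)=O)n3)c2)cc1`: 40.7%
compound 2 `CC(=O)Nc1nc(-c2cccc(NS(=O)(=O)c3ccc(Br)cc3)c2)cs1`: "not active" (no number reported)
compound 3 `CCCCC#Cc1ccc(S(=O)(=O)Nc2cccc(-c3csc(NC(C)=O)n3)c2)cc1`: 73.2%

In a functional assay on A-375 cells (Homo sapiens) for antiproliferative activity, read by trypan blue exclusion, with a stated time of 48 h, tested at 1 uM (a higher number here means a weaker effect of the compound at the concentration tested, a lower number a stronger effect), compound 1 gives 40.7% and compound 3 gives 73.2%. Compound 2 is reported as "not active" (no number reported), with no number attached. Compound 3 thus stands highest of the two numbers, beyond the scatter from compound 1. Within the data shown here, the single step within the measured set, a number 32.5 percentage points higher from compound 1 to compound 3 (beyond the scatter), is large and runs toward a weaker effect.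

Compound 4 `CC(=O)Nc1nc(-c2cccc(NS(=O)(=O)c3ccc(C#CCO)cc3)c2)cs1` is not yet measured. It differs from compound 3 by hydroxy in place of propyl on a saturated chain carbon bound to a triple-bonded carbon; read one bond further out, hex-1-yn-1-yl becomes 3-hydroxyprop-1-yn-1-yl. The step from compound 1 to compound 3 bears on this directly, as a further cut of the same chain, and compound 2, without any such chain, is not active. A further rise in the number, beyond the scatter, is therefore expected, a number 16.8 percentage points higher from compound 3 to compound 4 (beyond the scatter). Compound 4 is estimated at 90%, in a range from 72% to 100%, and a report of no number at all is a real possibility.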

Compound 4, a percentage reported as activity, at one concentration (the size of the read-out at that concentration, not a potency): 81.3%
Compound 4: middle estimate off by 8.7 percentage points, on the high side, within the range that was stated.
By their numbers in this assay, from the lowest: compound 1; then compounds 3 and 4 (each within the scatter of the next).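

In this assay, hydroxy in place of propyl on a saturated chain carbon bound to a triple-bonded carbon gives a number 8.1 percentage points higher from compound 3 to compound 4 (within the scatter) and so leaves the hex-1-yn-1-yl and 3-hydroxyprop-1-yn-1-yl compounds indistinguishable at this place. Hydroxy in place of pentyl at the same carbon gives a number 40.6 percentage points higher from compound 1 to compound 4 (beyond the scatter) and shows that a hydroxy-bearing short chain does not reach the reading of compound 1, which remains the only compound shown with a number set apart from the others. No measured evidence is available to explain these readings.

From the compounds shown here alone, whether an amine or a carboxylic acid in place of the hydroxy, or a longer chain ending in hydroxy, would read closer to compound 1 remains open. Compound 2 carries no number, so its distance from the alkyne compounds cannot be read.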